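A few compounds are considered here, and "the series" means these few. Any claim that something is new, unique, unknown or untested is made for them only; others in the source may bear on it.

This study follows small changes to a shared core of linked ring units, all judged in a functional assay on cells (Homo sapiens) for antiproliferative activity, read by MTT assay, with a stated time of 48 h; a lower number here means that less compound is needed, a higher number that more compound is needed for the effect. Compound 1, with the structure `CCCCCCCCO[C@@H]1O[C@@H](C)[C@H](OC(=O)CCCCC)[C@@H](O[C@@H]2O[C@@H](C)[C@H](OC(C)=O)[C@@H](O[C@@H]3O[C@@H](C)[C@H](O)[C@@H](O)[C@H]3OC(C)=O)[C@H]2OC(C)=O)[C@H]1O`, is the larger member. In this assay compound 1 gives 10 uM. Compound 2, with the structure `CCCCCCCCO[C@@H]1O[C@@H](C)[C@H](OC(=O)CCCCC)[C@@H](O[C@@H]2O[C@@H](C)[C@H](OC(C)=O)[C@@H](O)[C@H]2OC(C)=O)[C@H]1O`, lacks one of the ring units of compound 1 and carries a free hydroxy group in its place. In this assay compound 2 gives > 20 uM, which is a limit of the assay and not a number. Compound 2 is thus one of the values sitting at the limit of > 20 uM in this assay, at which 1 of the 2 values shown sits, so its true value is known only to lie past that point.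

Compound 3, with the structure `CCCCCCCCO[C@@H]1O[C@@H](C)[C@H](OC(=O)CCCCC)[C@@H](O[C@@H]2O[C@@H](C)[C@H](OC(C)=O)[C@@H](OC(C)=O)[C@H]2OC(C)=O)[C@H]1O`, differs from compound 2 in one place: acetyl in place of hydrogen on an oxygen on a saturated carbon. No measured pair here shows such a change on its own, so the size of the step in this assay cannot be read from the numbers shown; the expectation is a step no larger than the usual scatter, in either direction. Compound 3 is therefore expected to give about 25 uM, within a range from 8 uM to 80 uM. The expected step that the limit leaves unreadable from compound 2 to compound 3 is accordingly small.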

Compound 3, concentration for half-maximal effect: 14 uM
Beside the measured number, compound 3's estimate is 1.8-fold (0.25 log units) above it; measured number inside the range.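

In this assay, replacing hydrogen with acetyl on this oxygen, which turns the hydroxy into an acetoxy group, gives an at least 1.4-fold lower number from compound 2 to compound 3 (0.15 log units; that floor lies within the scatter). At this same oxygen, the acetyl of compound 3 gives 14 uM and the further ring unit of compound 1 gives 10 uM, so a measured number here does not depend on that ring unit being present. Compound 2 gives > 20 uM, which is a limit and not a number, so only a floor for the step is known, that floor lies within the scatter, and the true size of the step stays open: the limit of > 20 uM in this assay, at which 1 of the 3 values shown sits.

The compounds shown leave open how a benzoyl ester, a methyl ether or an amine at this oxygen would read, and so whether the acetyl itself matters or only the capping of the free hydroxy group. This single pair also cannot tell whether the same change would act alike on the other free hydroxy groups of the shared core.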